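Cytotoxicity notes: cyclopentyloxy to 3-chlorophenoxy on the shared core

The source may report more compounds than this note shows. Statements on the series, on what has been measured and on what is new or still open speak of the compounds shown alone.

Measured compounds:
compound 1, `Cc1cn(C2CCN(Cc3cccc(OC4CCCC4)c3)CC2)c(=O)[nH]c1=O`: 30300 nM
compound 2, `Cc1cn(C2CCN(Cc3cc(Oc4ccccc4)ccn3)CC2)c(=O)[nH]c1=O`: > 64000 nM

Readings come from an ADME assay on MRC5 cells (Homo sapiens) for cytotoxicity, read by fluorescence and resazurin assay, with a stated time of 3 days; a lower number here means a stronger inhibitor, a higher number a weaker inhibitor. In this assay, among the measured compounds shown here, compound 1 gives 30300 nM, the only number in the set. Compound 2 is reported only as a limit of the assay, > 64000 nM. For the measured compounds named here, the one piece of evidence on the set is the limit of > 64000 nM in this assay, at which 1 of the 2 values shown sits, so no step between measured compounds can be counted and no size of change has been observed.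

Compound 3, `Cc1cn(C2CCN(Cc3cccc(Oc4cccc(Cl)c4)c3)CC2)c(=O)[nH]c1=O`, is not yet measured in this assay. It differs from compound 1 in one place: 3-chlorophenyl in place of cyclopentyl on an oxygen on an aromatic ring. The change swaps cyclopentyloxy for 3-chlorophenoxy on an oxygen on an aromatic ring whose other neighbour is aromatic carbon.

Going by the values given here, with no measured step to lean on, the expected step from compound 1 to compound 3 is small, a 1.2-fold lower number from compound 1 to compound 3 (0.08 log units; within the scatter), and is not expected to exceed the usual scatter in either direction. Compound 3 is therefore estimated at 25000 nM, with a range from 10000 nM to 64000 nM.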

Compound 3, half-maximal inhibitory concentration: 21000 nM
Compound 3: the middle estimate sits 1.2-fold (0.08 log units) above what was measured; low and high end bracket the measured number.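

In this assay, among the compounds shown here, putting 3-chlorophenyl in place of cyclopentyl on an oxygen on an aromatic ring gives a 1.4-fold lower number from compound 1 to compound 3 (0.16 log units; within the scatter), the first step that can be read. At this position, then, the read-out does not separate a five-membered non-aromatic ring of carbon only from a six-membered aromatic ring of carbon only bearing chlorine, even though the entering group has 7 heavy atoms against 5 for the group that leaves. Compound 2 remains a limit of the assay and differs from compound 3 in more than one place, so it adds no readable step: the limit of > 64000 nM in this assay, at which 1 of the 3 values shown sits.

The groups compared here both count no hydrogen-bond donors or acceptors and no net charge, leaving open whether an amine or a carboxylic acid on that oxygen would give a step beyond the scatter. The step also carries the aromatic ring and the chlorine together, and a plain phenyl on the core of compound 1 would be needed to read them apart.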